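The source may report more compounds than this note shows. Statements on the series, on what has been measured and on what is new or still open speak of the compounds shown alone.

Measured compounds in a functional assay on HeLa cells (Homo sapiens) for antiproliferative activity, read by MTT assay, with a stated time of 48 h; on this read-out higher numbers stand for weaker inhibition and lower numbers for stronger inhibition:
- compound 1, `Cc1cnc(Nc2ccc(S(N)(=O)=O)cc2)nc1Nc1nc2ccccc2s1`, gives 2800 nM
- compound 2, `Cc1cnc(Nc2ccc(S(N)(=O)=O)cc2)nc1Nc1nc2ccc(Cl)cc2s1`, gives 3730 nM
- compound 3, `COc1ccc2nc(Nc3nc(Nc4ccc(S(N)(=O)=O)cc4)ncc3C)sc2c1`, gives 36700 nM

Compound 3 gives the highest number of the three in this assay: the step of a 13-fold higher number from compound 1 to compound 3 (1.12 log units; beyond the scatter) is large, and the step of a 9.8-fold higher number from compound 2 to compound 3 (0.99 log units; beyond the scatter) is modest, both beyond the scatter. The step of a 1.3-fold higher number from compound 1 to compound 2 (0.12 log units; within the scatter) stays within the scatter.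

Compound 4, `COc1ccc2nc(Nc3ccnc(Nc4ccc(S(N)(=O)=O)cc4)n3)sc2c1`, is not yet measured. It differs from compound 3 by hydrogen in place of methyl on an aromatic carbon. Within the data shown here, all three measured steps concern substituents on the fused bicyclic part of the shared core; none of them touches the methyl on the six-membered aromatic ring with two nitrogens, so no measured step bears directly on this change. Among the measured compounds shown here, with no precedent, the expectation for this assay is a step from compound 3 to compound 4 of no more than the scatter in either direction, a 1.1-fold higher number from compound 3 to compound 4 (0.04 log units; within the scatter). Compound 4 is therefore estimated at 40000 nM, with a range from 12000 nM to 130000 nM.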

Compound 4, half-maximal inhibitory concentration: 1730 nM
Compound 4: middle estimate off by 23-fold (1.36 log units), on the high side, and the stated range ends above it.
By their numbers in this assay, from the lowest: compounds 4, 1 and 2 (each within the scatter of the next, the first and the last beyond it); then compound 3.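

In this assay hydrogen in place of methyl on an aromatic carbon of the six-membered aromatic ring with 2 nitrogen gives a 21-fold lower number from compound 3 to compound 4 (1.33 log units; beyond the scatter) and is a large step. Among these compounds, the earlier steps all concerned substituents on the fused part of the shared core, so this is the first sign that the methyl position alone can move the number beyond the scatter, at least with the methoxy group present. No supporting measurement bears on the origin of this step.

On these data alone, whether removing the methyl gives a step of similar size from compound 1 or compound 2 remains open, so the step cannot yet be separated from the methoxy group. As far as these compounds go, how an ethyl group or an amine at this position would compare with hydrogen and methyl also remains open.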